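One More Carbon on the Chain of Compound 3

A few compounds are considered here, and "the series" means these few. Any claim that something is new, unique, unknown or untested is made for them only; others in the source may bear on it.

Compound 3 `CCCCNc1nc(N)nc(C)c1CCCC` carries a butyl chain on the shared core; in an assay on HEK293 cells for agonist activity at Toll-like receptor 8 (Homo sapiens), read by spectrophotometry (on this read-out lower numbers stand for an effect already at smaller amounts and higher numbers for an effect only at larger amounts of compound), compound 3 gives 780 nM. Among the three measured compounds this is the second highest number: compound 1 `CCCCNc1nc(N)nc(C)c1CCCCc1ccccc1` gives 857 nM, which lies within the scatter of compound 3, while compound 2 `CCCCNc1nc(N)nc(C)c1CCCN1CCN(C)CC1` gives 179 nM, the lowest of the set. Compound 4 `CCCCCc1c(C)nc(N)nc1NCCCC` differs from compound 3 by methyl in place of hydrogen on a saturated chain carbon, four bonds along the chain from an aromatic carbon. Two of the measured steps speak to this part of the molecule. The step of a 1.1-fold lower number from compound 1 to compound 3 (0.04 log units; within the scatter) shows that exchanging phenyl for hydrogen at this chain position leaves the number essentially unchanged. The larger shifts, a 4.8-fold lower number from compound 1 to compound 2 (0.68 log units; beyond the scatter) and a 4.4-fold higher number from compound 2 to compound 3 (0.64 log units; beyond the scatter), concern a 4-methylpiperazin-1-yl group three bonds along the chain from an aromatic carbon, so they bear less directly on a single added methyl. A step no larger than the scatter is therefore expected, a 1.1-fold lower number from compound 3 to compound 4 (0.05 log units; within the scatter). Compound 4 is estimated at 700 nM, within 350 nM to 1400 nM.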

Compound 4, half-maximal effective concentration: 1220 nM
Estimate against measurement, compound 4: 1.7-fold (0.24 log units) below; low and high end bracket the measured number.
By their numbers in this assay, from the lowest: compound 2; then compounds 3, 1 and 4 (each within the scatter of the next).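

In this assay, methyl in place of hydrogen on a saturated chain carbon, four bonds along the chain from an aromatic carbon, gives a 1.6-fold higher number from compound 3 to compound 4 (0.19 log units; within the scatter) and so stays within the scatter. Methyl in place of phenyl at that place gives a 1.4-fold higher number from compound 1 to compound 4 (0.15 log units; within the scatter) and also stays within it, so hydrogen, methyl and phenyl are not told apart at this chain carbon. Only the 4-methylpiperazin-1-yl chain of compound 2 stands apart, with ethyl in its place giving a 6.8-fold higher number from compound 2 to compound 4 (0.83 log units; beyond the scatter) and lying beyond the scatter.

From the compounds shown here alone, it stays open whether a simpler amine or an alcohol on the chain would give a number as low as that of compound 2, and whether a longer chain would leave the scatter. No measurement shown here accounts for these differences.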